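A few compounds are considered here, and "the series" means these few. Any claim that something is new, unique, unknown or untested is made for them only; others in the source may bear on it.

Going by the values given here, in a functional assay on HT-29 cells (Homo sapiens) for antiproliferative activity, read by MTT assay, with a stated time of 48 h (a lower number here means a stronger inhibitor of growth, a higher number a weaker inhibitor of growth), compound 2 `COC(=O)N1N=C(c2cccc(C)c2)CC1c1cc(OC)c(OC)c(OC)c1` gives 100 nM, the lower of the two numbers so far, and compound 1 `COC(=O)N1N=C(c2cccc(O)c2)CC1c1cc(OC)c(OC)c(OC)c1` gives 1350 nM. Compound 3 `COC(=O)N1N=C(c2cccc(Cl)c2)CC1c1cc(OC)c(OC)c(OC)c1` differs from compound 2 by one change: chloro in place of methyl on an aromatic carbon. Among the compounds with values here, only one measured step bears on this, the large 14-fold lower number from compound 1 to compound 2 (1.13 log units; beyond the scatter), with methyl in place of hydroxy. Within the data shown here, it shows that a single swap on an aromatic carbon can move the number far, but no measured compound carries chloro, so the direction stays open. The expected step is a 1.2-fold higher number from compound 2 to compound 3 (0.08 log units; within the scatter), with no shift beyond the scatter foreseen. For compound 3 the estimated value is 120 nM, within a range of 40 nM to 350 nM.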

Compound 3, concentration for 50% growth inhibition: 140 nM
The estimate for compound 3 lay 1.2-fold (0.07 log units) below the measured number, and the stated range covers the measured number.
By their numbers in this assay, from the lowest: compounds 2 and 3 (each within the scatter of the next); then compound 1.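

In this assay, the change from 3-methylphenyl to 3-chlorophenyl gives a 1.4-fold higher number from compound 2 to compound 3 (0.15 log units; within the scatter) and so leaves the number in place: at this position the two groups cannot be told apart. Chloro in place of hydroxy gives a 9.6-fold lower number from compound 1 to compound 3 (0.98 log units; beyond the scatter) and shows that the lower number seen with methyl is not unique to methyl. Nothing shown here explains why these two groups read alike. Still open, going by these compounds, is how an amine, a carboxylic acid or a longer chain would read at this position, and whether chloro elsewhere on this ring would match.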